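This account rests on a few compounds, and the source may have more. Where it says the series, first, only, none or still open, it means among the compounds named here.

Series notes. Three amides share one core and differ only in the amine on the aromatic carbon. Compound 1 `CN(c1ccc2cc(NC(=O)CCc3ccc(C(F)(F)F)cc3)ccc2n1)C1CCCCC1` in a functional assay on HEK293 cells for activation of melanin-concentrating hormone receptor 1 (Rattus norvegicus), read by inositol phosphate accumulation (on this read-out lower numbers stand for an effect already at smaller amounts and higher numbers for an effect only at larger amounts of compound), gives 1200 nM; compound 2 `O=C(CCc1ccc(C(F)(F)F)cc1)Nc1ccc2nc(N3CCC(c4ccccc4)C3)ccc2c1` gives 1770 nM; compound 3 `O=C(CCc1ccc(C(F)(F)F)cc1)Nc1ccc2nc(N3CCCCCC3)ccc2c1` gives 1800 nM. Where compound 3 stands among these numbers is told by the steps towards it: a 1.5-fold higher number from compound 1 to compound 3 (0.18 log units; within the scatter) and a 1.0-fold higher number from compound 2 to compound 3 (0.01 log units; within the scatter), both within the scatter, as is a 1.5-fold higher number from compound 1 to compound 2 (0.17 log units; within the scatter). Compound 4 `O=C(CCc1ccc(C(F)(F)F)cc1)Nc1ccc2nc(N3CC4CCC3C4)ccc2c1` carries a fourth amine: a group of 7 heavy atoms (6 carbon, 1 nitrogen; one five-membered non-aromatic ring of carbon only, one five-membered non-aromatic ring with 1 hetero atom) in place of a group of 7 heavy atoms (6 carbon, 1 nitrogen; one seven-membered non-aromatic ring with 1 hetero atom), on an aromatic carbon. The three amine exchanges measured so far bear on this one, and none of them moved the number beyond the scatter. No step beyond the scatter is therefore expected in this assay; the expected step is no change at the digits printed from compound 3 to compound 4 (within the scatter). Compound 4 is estimated at 1800 nM, with a range of 900 nM to 3600 nM.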

Compound 4, half-maximal effective concentration: 150 nM
Estimate against measurement, compound 4: 12-fold (1.08 log units) above; the whole stated range lies above it.
By their numbers in this assay, from the lowest: compound 4; then compounds 1, 2 and 3 (each within the scatter of the next).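

On this aromatic carbon, next to the ring nitrogen, the amine can move the number in this assay beyond the scatter: the exchange in a 12-fold lower number from compound 3 to compound 4 (1.08 log units; beyond the scatter) keeps the heavy-atom, donor and acceptor counts and alters only the ring arrangement. The other two amines give the same direction, with a 12-fold lower number from compound 2 to compound 4 (1.07 log units; beyond the scatter) and an 8.0-fold lower number from compound 1 to compound 4 (0.90 log units; beyond the scatter), so compound 4 stands apart from all three. No supporting evidence bears on this result. Going by these compounds, whether another two-ring amine, such as octahydroindol-1-yl, gives a similarly low number stays open. So does whether the effect of this amine persists with a longer chain on the amide.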